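The compounds below may be only part of what the source reports. "The series", "measured", "known", "first", "only" and "open" are said of these compounds alone.

Measured so far:
compound 1 `Cc1ccc2oc(SCC(=O)Nc3ccc(-c4nc(-c5ccccc5)c(-c5ccccc5)n4C)cc3)nc2c1`: 65.1%
compound 2 `Cn1c(-c2ccc(NC(=O)CSc3nc4ccccc4s3)cc2)nc(-c2ccccc2)c1-c1ccccc1`: 76.6%
compound 3 `Cn1c(-c2ccc(NC(=O)CSC3=NCCS3)cc2)nc(-c2ccccc2)c1-c1ccccc1`: 70%

In a functional assay on MCF7 cells (Homo sapiens) for cytotoxicity, read by MTT assay, with a stated time of 24 h, tested at 80 ug/mL (a lower number here means a weaker effect, a higher number a stronger effect of the compound at the concentration tested), compound 2 has the highest of the three numbers, but only its gap to compound 1 lies beyond the scatter; its value and that of compound 3 lie within it. Compound 4 `Cn1c(-c2ccc(NC(=O)CN3CCN(c4ccccc4)CC3)cc2)nc(-c2ccccc2)c1-c1ccccc1` is not yet measured; it differs from compound 2 in one place: 4-phenylpiperazin-1-yl in place of (1,3-benzothiazol-2-yl)sulfanyl on a saturated chain carbon bound to a carbonyl carbon. All measured steps exchange the group on the sulfur: a number 11.5 percentage points higher from compound 1 to compound 2 (beyond the scatter), a number 4.9 percentage points higher from compound 1 to compound 3 (within the scatter) and a number 6.6 percentage points lower from compound 2 to compound 3 (within the scatter). Here the whole (1,3-benzothiazol-2-yl)sulfanyl group leaves, a larger change than any measured. For compound 4 a step of a number 6.6 percentage points lower from compound 2 to compound 4 (within the scatter) is expected, small and downward, given the modest sizes of a number 4.9 percentage points higher from compound 1 to compound 3 (within the scatter) and a number 6.6 percentage points lower from compound 2 to compound 3 (within the scatter). Compound 4 is estimated at 70%, between 52% and 85%.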

Compound 4, a percentage reported as activity, at one concentration (the size of the read-out at that concentration, not a potency): 72.5%
The estimate for compound 4 lay 2.5 percentage points below the measured number, within the range that was stated.
By their numbers in this assay, from the lowest: compounds 1, 3, 4 and 2 (each within the scatter of the next, the first and the last beyond it).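

Swapping the whole (1,3-benzothiazol-2-yl)sulfanyl group for 4-phenylpiperazin-1-yl removes the sulfur link from the saturated chain carbon bound to a carbonyl carbon, yet in this assay the result is a number 4.1 percentage points lower from compound 2 to compound 4 (within the scatter) and the comparisons with the other two compounds give a number 2.5 percentage points higher from compound 3 to compound 4 (within the scatter) and a number 7.4 percentage points higher from compound 1 to compound 4 (within the scatter). So this position accepts a group attached through nitrogen, with all three steps within the scatter. Nothing available explains this tolerance.

Going by these compounds, it remains open whether the terminal phenyl or the piperazine ring matters, since every group here carries a ring. A dimethylamino group or a carboxylic acid on the same chain carbon would test whether any ring is needed at all.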